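The source may hold more compounds than are shown below. What is called first, only, known or untested is meant among the compounds shown, and "the series" means these compounds.

Compound 1 `c1ccc(-c2ccncc2)c(OCC2=NCCN2)c1` carries a pyridin-4-yl group on the shared core. In a functional assay for activation of Alpha-1B adrenergic receptor (Homo sapiens), read by calcium flux (on this read-out lower numbers stand for an effect already at smaller amounts and higher numbers for an effect only at larger amounts of compound), compound 1 gives < 100000 nM, which is a limit of the assay rather than a number. Compound 2 `Cc1cccc(-c2ccccc2OCC2=NCCN2)n1` gives < 100000 nM in this assay, again a limit. Both values sit at the limit of < 100000 nM in this assay, at which 2 of the 2 values shown sit, so compound 1 has no measured position on a numerical scale. Compound 3 `c1coc(-c2ccccc2OCC2=NCCN2)c1` differs by furan-2-yl in place of pyridin-4-yl on an aromatic carbon. Among the measured compounds shown here, with no measured step between compounds to go by, the expected step is a step that the limit leaves unreadable from compound 1 to compound 3, with no clear direction beyond the scatter. For compound 3 in this assay the estimate is 30000 nM, within 3000 nM to 100000 nM.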

Compound 3, half-maximal effective concentration: 10 nM
Beside the measured number, compound 3's estimate is 3000-fold (3.48 log units) above it; the measured number lies below the stated range.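

Among the compounds shown here, no step from compound 1 to compound 3 can be read in this assay, because compound 1 stands at a limit of the assay: the limit of < 100000 nM in this assay, at which 2 of the 3 values shown sit. The compounds shown leave open how large the change from pyridin-4-yl to furan-2-yl on the shared core is.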